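This account rests on a few compounds, and the source may have more. Where it says the series, first, only, none or still open, it means among the compounds named here.

Compound 1 `Cn1cc(-c2nc3c(-c4ccnc(OC5CC5)c4)cnn3cc2OCCCC(C)(C)O)cn1`: 2900 nM
Compound 2 `CNc1nc2c(-c3ccnc(OC)c3)cnn2cc1OC`: 310 nM

Both were tested in an assay on isolated protein for inhibition of activin receptor type-2A (Homo sapiens), read by 33P incorporation, with a stated time of 20 min, in the presence of a further agent that is not named here; a higher number here means a weaker inhibitor, a lower number a stronger inhibitor. Of the two numbers, compound 1 gives the higher one, 2900 nM, and compound 2 gives 310 nM; this gap lies beyond the usual scatter. Compound 3 `COc1cn2ncc(-c3ccnc(OC4CC4)c3)c2nc1-c1cnn(C)c1` has not yet been measured. It differs from compound 1 in one place: hydrogen in place of 3-hydroxy-3-methylbutyl on a saturated chain carbon bound to an oxygen on an aromatic ring. For the measured compounds named here, no measured pair shows this exact change, so its effect is unknown; the step from compound 1 to compound 3 is expected to be small, giving a somewhat lower number, a 1.9-fold lower number from compound 1 to compound 3 (0.29 log units; within the scatter). Compound 3 is therefore estimated at 1500 nM, between 500 nM and 5000 nM.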

Compound 3, half-maximal inhibitory concentration: 860 nM
Compound 3: the middle estimate sits 1.7-fold (0.24 log units) above what was measured; the measured number falls inside the stated range.
By their numbers in this assay, from the lowest: compound 2; then compound 3; then compound 1.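

In this assay, shortening the (4-hydroxy-4-methylpentyl)oxy group to methoxy gives a 3.4-fold lower number from compound 1 to compound 3 (0.53 log units; beyond the scatter) and leaves the rest of the molecule unchanged. This position therefore does not need the long chain or its hydroxyl group to retain inhibition, and the smaller group gives the stronger inhibitor of this pair. No available data explain why the number falls. Still open, as far as these compounds go, is how an ethoxy group, or a chain ending in an amine or a carboxylic acid, would behave at this position.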